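The compounds below may be only part of what the source reports. "The series", "measured", "known", "first", "only" and "open" are said of these compounds alone.

Of the compounds shown here, three have so far been tested in a functional assay on HepG2 cells (Homo sapiens) for cytotoxicity, with a stated time of 24 h; on this read-out lower numbers stand for stronger inhibition and higher numbers for weaker inhibition. Going by the values given here, compound 1 `O=C(N/N=C/c1cc(I)cc(I)c1O)c1ccccc1` is the first of them. In this assay compound 1 gives > 50000 nM, which is a limit of the assay rather than a number. Compound 2 `O=C(N/N=C/c1cc(I)c(O)c(I)c1)c1ccc(Br)cc1` is the second. In this assay compound 2 gives > 50000 nM, again a limit and not a number. Compound 3 `Cc1ccc(C(=O)NNC(=O)c2cc(I)cc(I)c2O)cc1` is the third. In this assay, among the compounds with values here, compound 3 gives 86400 nM, the only actual number among the three values shown. Compound 1 and compound 2 together account for (the limit of > 50000 nM in this assay, at which 2 of the 3 values shown sit). Compound 4 `CC(C)(C)c1ccc(C(=O)NNC(=O)c2cc(I)cc(I)c2O)cc1` has not yet been measured in this assay. It differs from compound 3 in one place: tert-butyl in place of methyl on an aromatic carbon. Within the data shown here, no measured pair of compounds shows what this change does here. Since compound 3 acts only weakly, as 86400 nM shows, a step no larger than the usual scatter is expected, in either direction. Compound 4 is therefore estimated at 80000 nM, between 30000 nM and 200000 nM. This estimate means an expected step of a 1.1-fold lower number from compound 3 to compound 4 (0.03 log units; within the scatter) that stays within the scatter.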

Compound 4, half-maximal inhibitory concentration: 87300 nM
Estimate against measurement, compound 4: 1.1-fold (0.04 log units) below, and the stated range covers the measured number.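

In this assay, replacing methyl with tert-butyl on this aromatic carbon, para to a large group, gives a 1.0-fold higher number from compound 3 to compound 4 (0.00 log units; within the scatter). Going by these compounds alone, this is the first measured pair, and it shows that going from 1 heavy atom to 4 heavy atoms here, with no ring, hydrogen-bond donor or acceptor, or net charge added, leaves the read-out where it was. The step comes from a set whose values all lie on the weak side of the read-out: the limit of > 50000 nM in this assay, at which 2 of the 4 values shown sit.

On these data alone, it remains open whether a different kind of group at this position, such as an amine or a carboxylic acid, would move the number. As far as these compounds go, it is also open whether the same swap would do as little in a compound that acts more strongly in this assay.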